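This account rests on a few compounds, and the source may have more. Where it says the series, first, only, none or still open, it means among the compounds named here.

Measured in a functional assay on K562 cells (Homo sapiens) for cytotoxicity, read by MTT assay, with a stated time of 3 days; a lower number here means a stronger inhibitor, a higher number a weaker inhibitor:
- compound 1 `N#Cc1c(O)nc(SCc2nc3ccccc3[nH]2)nc1-c1ccccc1`: 4.63 nM
- compound 2 `N#Cc1c(NN)nc(SCc2nc3ccccc3[nH]2)nc1-c1ccccc1`: 14.7 nM
- compound 3 `CCNc1nc(SCc2nc3ccccc3[nH]2)nc(-c2ccccc2)c1C#N`: 4.38 nM

These three compounds share a core and differ in a single group. Compound 3, which carries ethylamino, gives 4.38 nM and stands level with compound 1, which carries hydroxy. That swap amounts to a 1.1-fold lower number from compound 1 to compound 3 (0.02 log units; within the scatter). Compound 2, which carries aminoamino, is the one that stands apart, since replacing hydroxy with aminoamino gives a 3.2-fold higher number from compound 1 to compound 2 (0.50 log units; beyond the scatter).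

Compound 4 `N#Cc1c(Nc2nccs2)nc(SCc2nc3ccccc3[nH]2)nc1-c1ccccc1` has not been measured yet. It keeps the core of compound 3 and changes the same group, with 1,3-thiazol-2-yl in place of ethyl on a nitrogen on an aromatic ring. Going by the values given here, no measured compound has a ring on that nitrogen, so the three steps above can only suggest a likely size. The largest of them, a 3.4-fold lower number from compound 2 to compound 3 (0.53 log units; beyond the scatter), is modest, and the smallest stays within the scatter. A small rise in the number is therefore expected, and it may not clear the scatter. The expected change is a 1.6-fold higher number from compound 3 to compound 4 (0.20 log units; within the scatter). For compound 4 the estimate is 7 nM, with an expected range from 2.5 nM to 20 nM.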

Compound 4, half-maximal inhibitory concentration: 14.7 nM
The estimate for compound 4 lay 2.1-fold (0.32 log units) below the measured number; measured number inside the range.
By their numbers in this assay, from the lowest: compounds 3 and 1 (each within the scatter of the next); then compounds 2 and 4 (each within the scatter of the next).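

Compound 4 puts the first ring on this nitrogen, and in this assay replacing ethyl with 1,3-thiazol-2-yl gives a 3.4-fold higher number from compound 3 to compound 4 (0.53 log units; beyond the scatter), so a ring here does not hold the level set by ethyl. The new compound also lands level with the amino-bearing compound, with no change at the digits printed from compound 2 to compound 4 (within the scatter), although amino and 1,3-thiazol-2-yl are very different groups. Against hydroxy there is a 3.2-fold higher number from compound 1 to compound 4 (0.50 log units; beyond the scatter), so the four compounds fall into two levels, and the number does not simply climb with the size of the group, as both a smaller group than ethyl and a larger one give the higher reading.

The data shown offer nothing that explains this rise. As far as these compounds go, it remains open whether a phenyl ring or a saturated ring such as cyclohexyl on the same nitrogen would behave like 1,3-thiazol-2-yl, and whether a longer chain such as propyl would stay level with ethyl.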